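The source may hold more compounds than are shown below. What is called first, only, known or untested is meant among the compounds shown, and "the series" means these compounds.

Among the measured compounds shown here, compound 2 `COc1ccc(-c2cc3nccc(-c4cc(OC)c(OC)c(OC)c4)n3n2)cc1F` is the only member of the set that yields a number rather than a limit in a functional assay on HCT-116 cells (Homo sapiens) for inhibition, read by CCK-8 assay, with a stated time of 48 h; a higher number here means a weaker inhibitor, a lower number a stronger inhibitor; there compound 2 gives 2840 nM. Compound 1 `COc1ccc(-c2cc3nccc(-c4cc(OC)c(OC)c(OC)c4)n3n2)cc1[N+](=O)[O-]` reaches only the limit > 10000 nM in this assay. Compound 3 `Cc1ccc(-c2cc3nccc(-c4ccc(F)cc4)n3n2)cc1` likewise stops at the limit > 10000 nM. For the measured compounds named here, the single measured step, an at least 3.5-fold lower number from compound 1 to compound 2 (0.54 log units; beyond the scatter), is read against (the limit of > 10000 nM in this assay, at which 2 of the 3 values shown sit). Compound 4 `COc1cc(-c2ccnc3cc(-c4cccc(C)c4)nn23)cc(OC)c1OC` differs from compound 2 by 3-methylphenyl in place of 3-fluoro-4-methoxyphenyl on an aromatic carbon. Going by the values given here, no measured step covers this exchange; compound 3, which also carries a methyl-bearing phenyl, sits at a limit in this assay, and the methoxy that remains on compound 2 is lost. For compound 4 the expected step is a 2.8-fold higher number from compound 2 to compound 4 (0.45 log units; beyond the scatter). Compound 4 is accordingly estimated at 8000 nM, within 2500 nM to 25000 nM, with a real chance of a limit only.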

Compound 4, half-maximal inhibitory concentration: 6150 nM
Beside the measured number, compound 4's estimate is 1.3-fold (0.11 log units) above it; low and high end bracket the measured number.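

Putting 3-methylphenyl in place of 3-fluoro-4-methoxyphenyl gives a 2.2-fold higher number from compound 2 to compound 4 (0.34 log units; beyond the scatter) in this assay, a modest loss. Compound 4 is thus the second member with a number rather than a limit, so neither the fluoro nor the methoxy on this phenyl is required for a measurable number. The room for comparison remains narrow: the limit of > 10000 nM in this assay, at which 2 of the 4 values shown sit.

Whether the fluoro, the methoxy or the methyl carries the step remains unresolved, as all three change together. Also open, on these data alone, is how an amine or a carboxylic acid on this phenyl would move the number.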